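One methyl group removed from compound 1

The compounds below may be only part of what the source reports. "The series", "measured", "known", "first", "only" and "open" are said of these compounds alone.

Compound 1 `Cc1ccccc1C1CC(c2ccc(OCc3ccccc3)cc2)=NN1c1ccc(S(N)(=O)=O)cc1` gives 20000 nM
Compound 2 `Cc1ccc(C2CC(c3ccccc3)=NN2c2ccc(S(N)(=O)=O)cc2)cc1` gives 7000 nM

In an ADME assay on BHK-21 cells (Mesocricetus auratus) for cytotoxicity, read by MTT assay, with a stated time of 72 h (on this read-out lower numbers stand for higher toxicity in this test and higher numbers for lower toxicity in this test), compound 1 gives 20000 nM and so stands highest of the two measured compounds, above compound 2 at 7000 nM by more than the usual scatter. Compound 3 `NS(=O)(=O)c1ccc(N2N=C(c3ccc(OCc4ccccc4)cc3)CC2c2ccccc2)cc1` has not yet been measured. Its change from compound 1 is hydrogen in place of methyl on an aromatic carbon and amounts to hydrogen in place of methyl on an aromatic carbon, or 2-methylphenyl to phenyl. Going by the values given here, no measured pair of compounds shows this change alone, so the data give no direct size for it. Among the compounds with values here, with only this one change, the expected step of a 1.1-fold lower number from compound 1 to compound 3 (0.05 log units; within the scatter) stays within the scatter and has no clear direction. In this assay compound 3 is expected at 18000 nM (estimated range 7000 nM to 45000 nM).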

Compound 3, half-maximal cytotoxic concentration: 80000 nM
Compound 3: middle estimate off by 4.4-fold (0.65 log units), on the low side; measured number outside the range, above it.
By their numbers in this assay, from the lowest: compound 2; then compound 1; then compound 3.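

In this assay, hydrogen in place of methyl on an aromatic carbon, ortho to a large group, gives a 4.0-fold higher number from compound 1 to compound 3 (0.60 log units; beyond the scatter) as the only difference between the two structures. Going by these compounds alone, this is the first direct reading of this change: the methyl group at this place goes with the higher toxicity in this test, and compound 3 now stands highest of the three. No measurement shown explains the step.

From the compounds shown here alone, whether a chlorine atom, a methoxy group or an amine at this same place would give a number nearer compound 1 or nearer compound 3 remains open. So does whether the same change would give a step of similar size on a compound other than compound 1.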